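The compounds below may be only part of what the source reports. "The series", "measured", "known", "first", "only" and "open" are said of these compounds alone.

Measured compounds:
- Compound 1 `B[P@](=O)(OC[C@H]1O[C@@H](n2cc(OC)c(=O)[nH]c2=O)[C@H](O)[C@@H]1O)OP(=O)(O)OP(=O)(O)O`: in an in vitro functional assay on 1321-N1 cells for agonist activity at P2Y purinoceptor 6 (Homo sapiens), read by fluorescence, spectrophotometry and calcium flux (a lower number here means that less compound is needed, a higher number that more compound is needed for the effect), compound 1 gives 20100 nM.
- Compound 2 `B[P@@](=O)(OC[C@H]1O[C@@H](n2cc(OC)c(=O)[nH]c2=O)[C@H](O)[C@@H]1O)OP(=O)(O)OP(=O)(O)OC[C@H]1O[C@@H](n2cc(OC)c(=O)[nH]c2=O)[C@H](O)[C@@H]1O`: in this assay compound 2 gives 60 nM.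

Compound 2 stands lowest of the two numbers; compound 1 lies well above it, beyond the usual scatter. Compound 3 `B[P@](=O)(OC[C@H]1O[C@@H](n2cc(OC)c(=O)[nH]c2=O)[C@H](O)[C@@H]1O)OP(=O)(O)OP(=O)(O)OC[C@H]1O[C@@H](n2cc(OC)c(=O)[nH]c2=O)[C@H](O)[C@@H]1O` differs from compound 2 only in this way: the two compounds have the same atoms and bonds; at least one stereo element is drawn with a configuration in one of them and without one in the other: 1 of 11 stereo elements differ; a stereocentre at a phosphorus is drawn R in compound 2 and S in compound 3. For the measured compounds named here, no measured pair shows what an inversion at a phosphorus does here, so the direction of the step is open. A moderate rise of a 3.3-fold higher number from compound 2 to compound 3 (0.52 log units; beyond the scatter) is expected, with wide uncertainty. Compound 3 is estimated at 200 nM, within 40 nM to 2000 nM.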

Compound 3, half-maximal effective concentration: 2200 nM
Beside the measured number, compound 3's estimate is 11-fold (1.04 log units) below it; the measured number lies above the stated range.
By their numbers in this assay, from the lowest: compound 2; then compound 3; then compound 1.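

In this assay, the phosphorus stereocentre proves to matter on its own: with atoms and bonds unchanged, inversion there gives a 37-fold higher number from compound 2 to compound 3 (1.56 log units; beyond the scatter). For the compounds shown here, until now, no measured pair had isolated this centre. The reading carries one qualification: the fact that one of compounds 2 and 3 is drawn with a defined configuration and the other without, at the place where they differ

Open remains whether inversion at a phosphorus counts equally in compound 1, and whether it would count equally with an ethoxy group in place of the methoxy group.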